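The source may report more compounds than this note shows. Statements on the series, on what has been measured and on what is new or still open speak of the compounds shown alone.

In a functional assay on U-251 cells (Homo sapiens) for inhibition, read by MTT assay, with a stated time of 2 days (on this read-out lower numbers stand for stronger inhibition of growth and higher numbers for weaker inhibition of growth), compound 3 `COc1ccc(NC(=O)CNCCCC(=O)Nc2ccccc2N)cc1` gives > 100000 nM, which is a limit of the assay rather than a number. Compound 1 `Nc1ccccc1NC(=O)CCCNCC(=O)Nc1ccc(Cl)cc1` in this assay gives 75000 nM. Compound 1 differs from compound 3 only by chloro in place of methoxy on an aromatic carbon and that change yields an at least 1.3-fold lower number from compound 3 to compound 1 (0.12 log units; that floor lies within the scatter).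

Compound 2 `COc1ccc(NC(=O)CNc2ccc(C(=O)Nc3ccccc3N)cc2)cc1` gives > 100000 nM in this assay, again a limit and not a number. The weak activity of this small set is underlined by the limit of > 100000 nM in this assay, at which 2 of the 3 values shown sit.

Compound 4 `Nc1ccccc1NC(=O)c1ccc(NCC(=O)Nc2ccc(Cl)cc2)cc1` is not yet measured. For the measured compounds named here, it differs from compound 2 by chloro in place of methoxy on an aromatic carbon, the same change, made in the same place, as the one from compound 3 to compound 1. The difference between the cores of compound 2 and compound 3 is not broken down here.

For compound 4 the step from compound 2 is expected to be an at least 1.1-fold lower number from compound 2 to compound 4 (0.04 log units; that floor lies within the scatter), set beside the earlier at least 1.3-fold lower number from compound 3 to compound 1 (0.12 log units; that floor lies within the scatter), which itself lay within the scatter. Compound 4 is therefore estimated at 90000 nM, with a plausible range from 40000 nM to 200000 nM in this assay.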

Compound 4, concentration for total growth inhibition: 62500 nM
The estimate for compound 4 lay 1.4-fold (0.16 log units) above the measured number, within the range that was stated.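

Carried to the core of compound 2, chloro in place of methoxy gives an at least 1.6-fold lower number from compound 2 to compound 4 (0.20 log units; that floor lies within the scatter) in this assay. On these data alone, the value of compound 2 is a limit of the assay and not a number, so the true size of this step remains unknown, and the figure is only a floor. The two steps point the same way, which fits the change carrying over from one core to the other, but they do not show that it carries over by the same amount: the same change on two cores in this assay, an at least 1.3-fold lower number (0.12 log units; that floor lies within the scatter) from compound 3 to compound 1 and an at least 1.6-fold lower number (0.20 log units; that floor lies within the scatter) from compound 2 to compound 4; the limit leaves it open whether they differ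

The compounds shown leave open how a nitrile or a carboxylic acid in place of chloro on that ring would read in this assay, and whether a longer chain in the core of compound 3 would alter the step. As far as these compounds go, both steps start from a limit, so the size of this change on either core stays open until a methoxy compound has a number rather than a limit.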